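The source may hold more compounds than are shown below. What is called first, only, known or untested is meant among the compounds shown, and "the series" means these compounds.

Three compounds have already been measured in a physicochemical assay for lipophilicity, read by HPLC, measured as octanol-water partition, at pH 3; a higher number here means a more lipophilic compound, a lower number a more polar compound:

Compound 1, `CCN1CCC2(CC1)CC(=O)c1ccc3ccccc3c1O2`: 1.65
Compound 2, `c1ccc2c3c(ccc2c1)CCC1(CCNCC1)O3`: 1.97
Compound 3, `O=C1CC2(CCNCC2)Oc2c1ccc1ccccc21`: 1.48

Compound 2 gives the highest of the three numbers; its values lie beyond the scatter from both compound 1 and compound 3. Compound 1 and compound 3 share a core, and the difference between the core of compound 2 and the core of compound 3 is not broken down here.

One change appears twice in this set. From compound 3 to compound 1 it is ethyl in place of hydrogen on an amine nitrogen in a ring, and the measured step was a number 0.17 log units higher from compound 3 to compound 1 (within the scatter). The unmeasured compound 4, `CCN1CCC2(CCc3ccc4ccccc4c3O2)CC1`, carries the same change on the core of compound 2: ethyl in place of hydrogen on an amine nitrogen in a ring.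

Because the earlier change gave the step of a number 0.17 log units higher from compound 3 to compound 1 (within the scatter), a step of similar size, a number 0.28 log units higher from compound 2 to compound 4 (within the scatter), is expected from the second occurrence in this assay. On that basis compound 4 is estimated at 2.25, with the expected range running from 1.95 to 2.6.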

Compound 4, distribution coefficient: 2.17
Compound 4: the middle estimate sits 0.08 log units above what was measured; measured number inside the range.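

In this assay, ethyl in place of hydrogen on an amine nitrogen in a ring gives a number 0.20 log units higher from compound 2 to compound 4 (within the scatter), and the same change on the other core gives a number 0.17 log units higher from compound 3 to compound 1 (within the scatter). Across these two cores, then, the change behaves alike in one plain sense: neither step goes beyond the scatter, so the result for one core was a fair guide to the result for the other, but two steps of this size cannot show that the ethyl group has a real effect on the number on either core. No measurement is at hand that would explain these steps.

The compounds shown leave open whether a longer chain such as propyl or butyl, or a chain ending in a carboxylic acid, on the same nitrogen would give a step beyond the scatter. They also leave open whether the ethyl step would stay this size on any core other than these two.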